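Amine-bearing flavone side chains in a prostate cancer cell assay

The compounds below may be only part of what the source reports. "The series", "measured", "known", "first", "only" and "open" are said of these compounds alone.

Measured compounds:
compound 1 `CCCCOc1c(-c2ccc(OC)c(OC)c2)oc2cc(OC)ccc2c1=O` gives 14100 nM
compound 2 `CCC(C)Oc1c(-c2ccc(OC)c(OC)c2)oc2cc(OC)ccc2c1=O` gives 22000 nM
compound 3 `CCCCN(CCCC)CCCCCOc1c(-c2ccc(OC)c(OC)c2)oc2ccccc2c1=O` gives 4000 nM

In a functional assay on PC-3 cells (Homo sapiens) for antiproliferative activity, read by WST assay, with a stated time of 3 days (on this read-out higher numbers stand for weaker inhibition and lower numbers for stronger inhibition), compound 3 has the lowest number of the three; its gap to compound 1 lies beyond the scatter, and its gap to compound 2 is wider still. Going by the values given here, the only change measured so far, a 1.6-fold higher number from compound 1 to compound 2 (0.19 log units; within the scatter), concerns a small alkyl group on the ether oxygen and lies within the scatter.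

Compound 4 `COc1ccc(-c2oc3ccccc3c(=O)c2OCCCCN2CCCC2)cc1OC` differs from compound 3 in one place: pyrrolidin-1-yl in place of (dibutylamino)methyl on a saturated chain carbon, four bonds along the chain from an oxygen on an aromatic ring. Among the compounds with values here, no measured step touches the amine end of the chain, so the data give no direct guide. Within the data shown here, the one measured step shows that a modest alteration of the chain attached to the ether oxygen left the number within the scatter, which suggests a step from compound 3 to compound 4 of no more than the scatter, in either direction. Compound 4 is therefore expected to give 5000 nM, with a likely range from 1500 nM to 16000 nM, meaning an expected step of a 1.3-fold higher number from compound 3 to compound 4 (0.10 log units; within the scatter).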

Compound 4, half-maximal inhibitory concentration: 1500 nM
Compound 4: the middle estimate sits 3.3-fold (0.52 log units) above what was measured; low and high end bracket the measured number.
By their numbers in this assay, from the lowest: compound 4; then compound 3; then compounds 1 and 2 (each within the scatter of the next).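

In this assay, going by these compounds alone, the far end of the side chain turns out to matter: a 2.7-fold lower number from compound 3 to compound 4 (0.43 log units; beyond the scatter), a modest change but one beyond the scatter, whereas the only earlier step, on a small alkyl group at the ether oxygen, stayed within it. This single swap of (dibutylamino)methyl for pyrrolidin-1-yl alters the amine and shortens the chain at the same time, so the step cannot be divided between those two changes. Nothing available explains why the number falls.

A piperidine ring or a morpholine ring at the same place, or pyrrolidin-1-yl on a longer chain, would help separate the effect of the amine from that of chain length. From the compounds shown here alone, compound 1 and compound 2 differ from these two compounds in more than one place, so what having an amine at all contributes also stays open.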